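The compounds below may be only part of what the source reports. "The series", "measured", "known", "first", "only" and "open" are said of these compounds alone.

In a functional assay on HeLa cells (Homo sapiens) for cytotoxicity, read by MTT assay, with a stated time of 48 h (on this read-out lower numbers stand for stronger inhibition and higher numbers for weaker inhibition), compound 3 `C=CC(C)(O)CC[C@@H]1C(=C)CC[C@H](Br)[C@@]1(C)CCC(O)C(C)(C)O` gives only a limit, > 100000 nM, and not a number. Compound 1 `C=CC(C)(O)CC[C@@H]1C(=C)CC[C@H](Br)[C@@]1(C)CCC(O)C(C)(C)Cl` gives 61000 nM. Compound 2 `C=CC(C)(O)CC[C@@H]1C(=C)CC[C@H](Br)[C@@]1(C)CCC(Br)C(C)(C)O` gives 91800 nM; 47400 nM (2 entries). Compound 4 `C=CC(C)(O)CC[C@@H]1C(=C)CC[C@H](Br)[C@@]1(C)CCC(OC)C(C)(C)O` differs from compound 3 by methyl in place of hydrogen on an oxygen on a saturated carbon, which is methyl in place of hydrogen on an oxygen on a saturated carbon, or hydroxy to methoxy. For the measured compounds named here, the one measured step is an at least 1.6-fold higher number from compound 1 to compound 3 (0.21 log units; that floor lies within the scatter). It swaps chloro for hydroxy, a different change, so it offers only weak guidance. No step beyond the scatter is expected in this assay, the estimate being an at least 1.1-fold lower number from compound 3 to compound 4 (0.04 log units; that floor lies within the scatter). Compound 4 is expected near 90000 nM, with an estimated range of 40000 nM to 200000 nM.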

Compound 4, half-maximal inhibitory concentration: > 100000 nM
Compound 4: a limit, no number; the forecaster's own chance of this, stated with the estimate: 45%; middle value at least 1.1-fold (0.04 log units) from the limit.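

In this assay compound 4 gives only a limit, not a number, so replacing the hydroxy with methoxy at this position produces no readable gain in potency. The step from compound 3 cannot be read because both compounds sit at the same limit: the limit of > 100000 nM in this assay, at which 2 of the 4 values shown sit. Against the chloro compound there is an at least 1.6-fold higher number from compound 1 to compound 4 (0.21 log units; that floor lies within the scatter), which stays within the scatter.

On these data alone, what remains open is how far these compounds lie past the limit. As far as these compounds go, it is also open whether an amine or a longer chain on this oxygen-bearing carbon would yield a measurable value.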